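Working notes: removing one fluoro from compound 2

A few compounds are considered here, and "the series" means these few. Any claim that something is new, unique, unknown or untested is made for them only; others in the source may bear on it.

- compound 1 `CC(C)NC(=N)NC(=N)Nc1ccc(C(F)(F)F)cc1`: 3200 nM
- compound 2 `CC(C)NC(=N)NC(=N)Nc1ccc(F)c(F)c1`: 26000 nM

In a functional assay on A2780 cells (Homo sapiens) for antiproliferative activity, read by MTT assay, with a stated time of 72 h (a higher number here means a weaker inhibitor, a lower number a stronger inhibitor), compound 2 gives 26000 nM, the higher of the two numbers, and compound 1 lies lower by more than the scatter. Compound 3 `CC(C)NC(=N)NC(=N)Nc1ccc(F)cc1` differs from compound 2 by a single change, hydrogen in place of fluoro on an aromatic carbon. Among the measured compounds shown here, no measured pair shows this change on its own, so the estimate is loose. A modest rise in the number is expected, possibly not beyond the scatter. The expected step is a 1.5-fold higher number from compound 2 to compound 3 (0.16 log units; within the scatter). Compound 3 is estimated at 38000 nM, with an expected range of 14000 nM to 100000 nM.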

Compound 3, half-maximal inhibitory concentration: 28000 nM
The estimate for compound 3 lay 1.4-fold (0.13 log units) above the measured number; low and high end bracket the measured number.
By their numbers in this assay, from the lowest: compound 1; then compounds 2 and 3 (each within the scatter of the next).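

In this assay, hydrogen in place of fluoro on this aromatic carbon, ortho to a fluoro group, makes no readable difference: a 1.1-fold higher number from compound 2 to compound 3 (0.03 log units; within the scatter). The clear separation appears instead with fluoro in place of trifluoromethyl, an 8.8-fold higher number from compound 1 to compound 3 (0.94 log units; beyond the scatter), so within these compounds the change at that other place, not the loss of the second fluoro, separates the values. Nothing available accounts for either step.

Still open, going by these compounds, is whether a larger group at the first position, such as methoxy or a nitrile, would also leave the value unchanged. On these data alone, whether an amine or a carboxylic acid would be tolerated in place of trifluoromethyl also remains open.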